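This account rests on a few compounds, and the source may have more. Where it says the series, first, only, none or still open, it means among the compounds named here.

Working notes on the series. Compound 1 `ClCCOC[C@@H]1CO1`, compound 2 `OC(C[C@@H]1COCCO1)C[C@@H]1COCCO1` and compound 3 `ON=C(C[C@@H]1COCCO1)C[C@@H]1COCCO1` have all been run in an ADME assay on BHK cells (Mesocricetus auratus) for cytotoxicity, read by XTT assay; on this read-out lower numbers stand for higher toxicity in this test and higher numbers for lower toxicity in this test. In this assay compound 1 reaches only the limit, > 5000000 nM. In this assay compound 2 likewise returns a limit, > 1000000 nM. In this assay compound 3 also returns a limit, > 1000000 nM. Compound 3 therefore stands at the limit of > 1000000 nM in this assay, at which 2 of the 3 values shown sit, with no number of its own, while the limit of > 5000000 nM in this assay, at which 1 of the 3 values shown sits, is the other boundary seen in this set. Compound 4 `CON=C(C[C@@H]1COCCO1)C[C@@H]1COCCO1` differs from compound 3 by methyl in place of hydrogen on an oxygen. Going by the values given here, no step between measured compounds exists here, so this change is expected to bring no shift beyond the usual scatter in this assay. Compound 4 is estimated at 1000000 nM, between 500000 nM and 2000000 nM, meaning an expected step of a number no higher from compound 3 to compound 4 (the limit leaves the size open).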

Compound 4, half-maximal cytotoxic concentration: > 1000000 nM
Compound 4: no number, only a limit (the forecaster's own chance of this, stated with the estimate: 85%); the middle value sits exactly at the limit.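

Compound 3 and compound 4 each return only a limit in this assay, so no step can be read between them. The compounds shown leave open what effect methyl in place of hydrogen on this oxygen has on cytotoxicity.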